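Changing one large group on compound 2

A few compounds are considered here, and "the series" means these few. Any claim that something is new, unique, unknown or untested is made for them only; others in the source may bear on it.

In an in vivo ADME assay on the whole organism for metabolic stability, with Rattus norvegicus as the target, at a dose of 1 mg/kg by the intravenous route (a higher number here means that the compound lasts longer, a lower number that the compound disappears faster), compound 1 (`CC/C(O)=C(\C#N)C(=O)Nc1ccc(OS(=O)(=O)C(F)(F)F)cc1`) gives 8 h, and compound 2 (`CC/C(O)=C(\C#N)C(=O)Nc1ccc(OS(=O)(=O)C(F)(F)F)c(C(=O)OC)c1`) gives 2 h, the lower of the two numbers. Compound 3 (`CC/C(O)=C(\C#N)C(=O)Nc1ccc(-c2ccc(F)cc2)c(C(=O)OC)c1`) has not yet been measured. It differs from compound 2 at a single place: 4-fluorophenyl in place of ((trifluoromethyl)sulfonyl)oxy on an aromatic carbon. That is, 4-fluorophenyl stands in place of ((trifluoromethyl)sulfonyl)oxy on an aromatic carbon.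

Among the compounds with values here, no measured step involves this swap, so the data give no direct guide to its size or direction. Within the data shown here, the only measured step, a 4.0-fold lower number from compound 1 to compound 2 (0.60 log units; beyond the scatter), comes from adding methoxycarbonyl in place of hydrogen at a different place. It serves only as a rough yardstick for how far one change has moved this number. The step expected here is a 1.5-fold higher number from compound 2 to compound 3 (0.18 log units; within the scatter), a small one with an uncertain direction. Compound 3 is estimated at 3 h, with an expected range of 1 h to 8 h.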

Compound 3, half-life: 0.9 h
Beside the measured number, compound 3's estimate is 3.3-fold (0.52 log units) above it; measured number below the stated range.
By their numbers in this assay, from the lowest: compound 3; then compound 2; then compound 1.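

In this assay, 4-fluorophenyl in place of ((trifluoromethyl)sulfonyl)oxy gives a 2.2-fold lower number from compound 2 to compound 3 (0.35 log units; beyond the scatter) and so shows that the group on this aromatic carbon, ortho to a methoxycarbonyl group, can move the half-life. The earlier compounds had shown such a move only for adding methoxycarbonyl, so a second place on the molecule now matters for this number. The entering group brings a ring and no hydrogen-bond acceptors while the leaving group has no ring and three of them, but these differences arrive together in one swap, and no measurement at hand explains the fall.

On these data alone, whether the same swap would also lower the number on compound 1, which has no methoxycarbonyl group, stays open. So does how a plain phenyl ring without its fluorine, or an amine, would fare on this carbon.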